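Removing the pyrazolyl substituent: compound 3 to compound 4

The source may hold more compounds than are shown below. What is called first, only, known or untested is meant among the compounds shown, and "the series" means these compounds.

Among the compounds with values here, compound 3 `COc1cc(-c2ccnc3cc(-c4ccc(-c5cnn(C)c5)cc4)nn23)cc(OC)c1OC` gives 274 nM in a functional assay on MCF7 cells (Homo sapiens) for inhibition, read by CCK-8 assay, with a stated time of 48 h (a lower number here means a stronger inhibitor, a higher number a weaker inhibitor), the highest of the three numbers so far: compound 1 `COc1cc(-c2ccnc3cc(-c4ccc(C)cc4)nn23)cc(OC)c1OC` gives 47 nM and compound 2 `COc1cc(-c2ccnc3cc(-c4ccc5ccn(C)c5c4)nn23)cc(OC)c1OC` gives 74 nM. Compound 4 `COc1cc(-c2ccnc3cc(-c4ccccc4)nn23)cc(OC)c1OC` differs from compound 3 by hydrogen in place of 1-methyl-1H-pyrazol-4-yl on an aromatic carbon. The step that bears on this is a 5.8-fold higher number from compound 1 to compound 3 (0.77 log units; beyond the scatter), where the 1-methyl-1H-pyrazol-4-yl group entered in place of methyl; compound 4 undoes that entry, though with hydrogen rather than methyl at that carbon. The step of a 1.6-fold higher number from compound 1 to compound 2 (0.20 log units; within the scatter) shows that another group on the same aromatic carbon changed little. For compound 4 a step of a 4.6-fold lower number from compound 3 to compound 4 (0.66 log units; beyond the scatter) is therefore expected, back toward the level seen with methyl in place. The estimate for compound 4 is 60 nM, with a range of 25 nM to 150 nM.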

Compound 4, half-maximal inhibitory concentration: 254 nM
Compound 4: middle estimate off by 4.2-fold (0.63 log units), on the low side; measured number above the stated range.
By their numbers in this assay, from the lowest: compounds 1 and 2 (each within the scatter of the next); then compounds 4 and 3 (each within the scatter of the next).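

In this assay, the step of a 1.1-fold lower number from compound 3 to compound 4 (0.03 log units; within the scatter) leaves the 1-methyl-1H-pyrazol-4-yl group and hydrogen not told apart at this aromatic carbon. The methyl and 1-methyl-1H-indol-6-yl groups are the ones that stand apart: hydrogen in place of methyl gives a 5.4-fold higher number from compound 1 to compound 4 (0.73 log units; beyond the scatter), and phenyl in place of 1-methyl-1H-indol-6-yl gives a 3.4-fold higher number from compound 2 to compound 4 (0.54 log units; beyond the scatter). No measurement here accounts for these differences.

Open, on these data alone, is how far the benefit of methyl extends to other small groups at this carbon. An ethyl group, a methoxy group or a chlorine atom there would test this.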